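Lengthening an Alkenyl Chain on a Shared Core

The compounds below may be only part of what the source reports. "The series", "measured", "known", "first", "only" and "open" are said of these compounds alone.

Compound 1 `C=CCCCCOc1ccccc1-c1cnc(OCCCC=C)n1C` gives 19000 nM in a functional assay on SK-MEL-28 cells (Homo sapiens) for inhibition, read by colorimetric assay and MTT assay, with a stated time of 72 h; a higher number here means a weaker inhibitor, a lower number a stronger inhibitor. Compound 2 `C=CCCCCCOc1ncc(-c2ccccc2OCCCCC=C)n1C` gives 79000 nM in this assay. The step between them, a 4.2-fold higher number from compound 1 to compound 2 (0.62 log units; beyond the scatter), comes from the change (but-3-en-1-yl in place of vinyl on a saturated chain carbon, three bonds along the chain from an oxygen on an aromatic ring). Compound 3 `C=CCCOc1ncc(-c2ccccc2OC)n1C` gives 21000 nM; how its core differs from that of compound 1 is not broken down here. Compound 4 `C=CCCCCOc1ncc(-c2ccccc2OC)n1C` has not yet been measured and differs from compound 3 by but-3-en-1-yl in place of vinyl on a saturated chain carbon, two bonds along the chain from an oxygen on an aromatic ring. The places differ: in compound 4 the change sits two bonds along the chain from an oxygen on an aromatic ring, whereas in compound 2 it sits three bonds along, so this is the same kind of change, not the same. The expected step of a 3.1-fold higher number from compound 3 to compound 4 (0.49 log units; beyond the scatter) rests on the earlier step of a 4.2-fold higher number from compound 1 to compound 2 (0.62 log units; beyond the scatter). Compound 4 is therefore estimated at 65000 nM, between 25000 nM and 160000 nM.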

Compound 4, half-maximal inhibitory concentration: 13000 nM
Estimate against measurement, compound 4: 5.0-fold (0.70 log units) above, and the stated range ends above it.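

In this assay, the lengthening of the chain gives a 1.6-fold lower number from compound 3 to compound 4 (0.21 log units; within the scatter), so no change can be read from it on this core. Carried from one core to another, the same change did not keep its size: the same change on two cores in this assay, a 4.2-fold higher number (0.62 log units; beyond the scatter) from compound 1 to compound 2 and a 1.6-fold lower number (0.21 log units; within the scatter) from compound 3 to compound 4, 6.7-fold (0.83 log units) apart, beyond the scatter of two such steps This shows that the step seen on the core of compound 1 could not be carried over to the core of compound 3, but it does not show what sets the two apart, as the change also sits at a different place along the chain and each core offers only one pair.

From the compounds shown here alone, whether further pairs on either core would follow one step or the other remains open. Going by these compounds, it is also open how a chain carrying an amine or a carboxylic acid would behave on these cores.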